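Working notes: from 2-chlorophenyl to 4-chlorophenyl

This account rests on a few compounds, and the source may have more. Where it says the series, first, only, none or still open, it means among the compounds named here.

In a functional assay on UACC-62 cells (Homo sapiens) for cytotoxicity, read by sulforhodamine B assay (on this read-out lower numbers stand for stronger inhibition of growth and higher numbers for weaker inhibition of growth), three compounds sharing one core have been measured. Compound 1 (`CC1=CC[C@@H]([C@@](C)(O)CCCC(C)(C)NC(=S)NN)CC1`) gives 18500 nM, and compound 2 (`CC1=CC[C@@H]([C@@](C)(O)CCCC(C)(C)NC(=S)N/N=C\c2ccc([N+](=O)[O-])cc2)CC1`) gives 20800 nM. Compound 3 (`CC1=CC[C@@H]([C@@](C)(O)CCCC(C)(C)NC(=S)N/N=C\c2ccccc2Cl)CC1`) gives 53300 nM, the highest of the three numbers, and its steps to both others lie beyond the scatter. Compound 4 (`CC1=CC[C@@H]([C@@](C)(O)CCCC(C)(C)NC(=S)N/N=C\c2ccc(Cl)cc2)CC1`) has not been measured. It differs from compound 3 as follows: 4-chlorophenyl in place of 2-chlorophenyl on a carbon with a double bond to nitrogen. In words, 4-chlorophenyl stands in place of 2-chlorophenyl on a carbon with a double bond to nitrogen.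

Among the compounds with values here, two measured steps bear on this change. The closer is a 2.6-fold higher number from compound 2 to compound 3 (0.41 log units; beyond the scatter), where 2-chlorophenyl replaces 4-nitrophenyl at the same place. The other is a 2.9-fold higher number from compound 1 to compound 3 (0.46 log units; beyond the scatter), where the group carrying 2-chlorophenyl is added. Both are modest. Neither moves a chlorine, so the data give no direct measure of this change. Within the data shown here, the only guide is compound 2, the sole measured compound with a 4-substituted phenyl, at 20800 nM.

A small move to a lower number in this assay is therefore expected, not clearly beyond the scatter. The estimated step is a 1.9-fold lower number from compound 3 to compound 4 (0.28 log units; within the scatter). For compound 4 the expected value is 28000 nM, with an estimated range of 13000 nM to 58000 nM.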

Compound 4, concentration for 50% growth inhibition: 7350 nM
Beside the measured number, compound 4's estimate is 3.8-fold (0.58 log units) above it; the whole stated range lies above it.
By their numbers in this assay, from the lowest: compound 4; then compounds 1 and 2 (each within the scatter of the next); then compound 3.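

In this assay, within the data shown here, moving the chlorine alone gives a 7.3-fold lower number from compound 3 to compound 4 (0.86 log units; beyond the scatter), the first direct reading at this position, and it shows that the place of the chlorine on the phenyl ring changes the result even though the atoms stay the same. Chloro in place of nitro on an aromatic carbon gives a 2.8-fold lower number from compound 2 to compound 4 (0.45 log units; beyond the scatter), so the identity of the group also counts when both groups are in the 4-substituted phenyl form. Among these compounds, the earlier 2.9-fold higher number from compound 1 to compound 3 (0.46 log units; beyond the scatter) had suggested that the added group carrying the chlorophenyl only weakens growth inhibition, but a 2.5-fold lower number from compound 1 to compound 4 (0.40 log units; beyond the scatter) reverses that direction, leaving compound 3 as the one that goes against any general benefit from the added group, and compound 4 as the only one of the added-group compounds whose step from compound 1 is to a lower number.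

Still open, from the compounds shown here alone, is how 3-chlorophenyl, 4-fluorophenyl, 4-methoxyphenyl or an unsubstituted phenyl would read at this carbon, and so whether the chlorine's place or the chlorine itself carries the trend. Nothing available here accounts for the difference between 2-chlorophenyl and 4-chlorophenyl.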